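From 4-bromophenoxy to 3-chlorophenoxy at the assay limit

The source may report more compounds than this note shows. Statements on the series, on what has been measured and on what is new or still open speak of the compounds shown alone.

Values in a functional assay on HeLa cells (Homo sapiens) for cytotoxicity, read by MTT assay, with a stated time of 48 h (on this read-out higher numbers stand for weaker inhibition and lower numbers for stronger inhibition), follow:
- Compound 1 `COc1ccc(/C=C/C(=O)/C=C/c2cc3ccccc3nc2Cl)c(OC)c1` gives > 10000 nM as a limit
- Compound 2 `COc1ccc(/C=C/C(=O)/C=C/c2cc3ccccc3nc2Oc2ccccc2)c(OC)c1` gives > 10000 nM as a limit
- Compound 3 `COc1ccc(/C=C/C(=O)/C=C/c2cc3ccccc3nc2Oc2ccc(Br)cc2)c(OC)c1` gives > 10000 nM as a limit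

Compound 3 gives > 10000 nM as a limit, not a number. The whole set shows the limit of > 10000 nM in this assay, at which 3 of the 3 values shown sit, and nothing finer. Compound 4 `COc1ccc(/C=C/C(=O)/C=C/c2cc3ccccc3nc2Oc2cccc(Cl)c2)c(OC)c1` differs from compound 3 by one change (3-chlorophenyl in place of 4-bromophenyl on an oxygen on an aromatic ring), namely 3-chlorophenyl in place of 4-bromophenyl on an oxygen on an aromatic ring. Among the measured compounds shown here, the steps that bear on it are a step that the two limits leave unreadable from compound 2 to compound 3 and a step that the two limits leave unreadable from compound 1 to compound 2 and also a step that the two limits leave unreadable from compound 1 to compound 3 and none of them has a readable size. No step beyond the scatter, in either direction, is therefore expected in this assay for this swap. The expected move is a step that the limit leaves unreadable from compound 3 to compound 4 as an estimate only. For compound 4 the estimated value is 12000 nM with an expected range from 5000 nM to 30000 nM and a further limit is likely.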

Compound 4, half-maximal inhibitory concentration: > 10000 nM
Compound 4: only a limit was reported; the forecaster's own chance of this, stated with the estimate: 80%; the middle value lies beyond the limit too.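

In this assay compound 4 gives > 10000 nM as a limit, not a number. No step from compound 1, compound 2 or compound 3 to compound 4 can be read, because all the values are limits: the limit of > 10000 nM in this assay, at which 4 of the 4 values shown sit.

From the compounds shown here alone, how strongly any of these four compounds acts on the cells, and whether swapping the group on the oxygen changes that, stays open.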